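A few compounds are considered here, and "the series" means these few. Any claim that something is new, unique, unknown or untested is made for them only; others in the source may bear on it.

Compound 3 `CCOC(=O)CCCCCOc1cccc(CN(C(=O)c2ccc(-c3cccc(OC(C)C)c3)cc2)C(C)C)c1` was tested in an ADME assay on HepG2 cells (Homo sapiens) for cytotoxicity, read by CellTiter-Glo and resazurin assay, with a stated time of 72 h; a lower number here means that less compound is needed, a higher number that more compound is needed for the effect. There compound 3 gave only a limit, > 26000 nM, not a number. Compound 1 `CC(C)Oc1cccc(-c2ccc(C(=O)N(Cc3cccc(OCCCCCC(=O)O)c3)C(C)C)cc2)c1` likewise gave only a limit, > 26000 nM. Compound 2 `COc1cc(OC)cc(-c2ccc(C(=O)N(Cc3cccc(OCCCCCC(=O)O)c3)C(C)C)cc2)c1` also gave only a limit, > 26000 nM. The two measured steps, a step that the two limits leave unreadable from compound 1 to compound 2 and a step that the two limits leave unreadable from compound 1 to compound 3, are therefore unreadable in size and direction. Compound 4 `CCOC(=O)CCCCCOc1cccc(CN(C(=O)c2ccc(Br)cc2)C(C)C)c1` differs from compound 3 by bromo in place of 3-isopropoxyphenyl on an aromatic carbon. Neither measured step involves a change of this kind, and because of the limit of > 26000 nM in this assay, at which 3 of the 3 values shown sit, no step beyond the scatter can be read in this assay from any of them. Compound 4 is therefore expected to remain at or near the same limit, with an estimated step that the limit leaves unreadable from compound 3 to compound 4. For compound 4 the estimated value is 30000 nM, within 10000 nM to 100000 nM.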

Compound 4, half-maximal effective concentration: > 26000 nM
Compound 4 ended at the assay's limit; the forecaster's own chance of this, stated with the estimate: 80%; the middle value lies beyond the limit too.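

No size or direction can be read for the change from compound 3 to compound 4, because both gave only a limit: the limit of > 26000 nM in this assay, at which 4 of the 4 values shown sit.

The compounds shown leave open what concentration of any of them reaches the half-maximal effect in this assay, and whether bromo in place of 3-isopropoxyphenyl changes it at all.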